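This account rests on a few compounds, and the source may have more. Where it says the series, first, only, none or still open, it means among the compounds named here.

Measured compounds:
Compound 1 `Nc1nc(N)c2cc(CSC(=S)N3CCN(C4CCCCC4)CC3)ccc2n1`, giving 4710 nM in a functional assay on A549 cells (Homo sapiens) for antiproliferative activity, read by MTT assay, with a stated time of 72 h; a lower number here means a stronger inhibitor, a higher number a weaker inhibitor.
Compound 2 `Nc1nc(N)c2cc(CSC(=S)N3CCN(c4ccc(F)cc4F)CC3)ccc2n1`, giving 5120 nM.
Compound 3 `CC(=O)c1ccc(N2CCN(C(=S)SCc3ccc4nc(N)nc(N)c4c3)CC2)cc1`, giving 2550 nM.

Among these three numbers compound 1 stands second highest. Its nearest neighbour is compound 2, reached by a 1.1-fold higher number from compound 1 to compound 2 (0.04 log units; within the scatter), and its furthest is compound 3, reached by a 1.8-fold lower number from compound 1 to compound 3 (0.27 log units; within the scatter). The remaining pair shows a 2.0-fold lower number from compound 2 to compound 3 (0.30 log units; within the scatter). Every one of these steps lies within the scatter, so the three compounds cannot be ranked against one another in this assay.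

Compound 4 `Nc1nc(N)c2cc(CSC(=S)N3CCN(c4ncccn4)CC3)ccc2n1` has not yet been measured. It differs from compound 1 in a single place: pyrimidin-2-yl in place of cyclohexyl on an amine nitrogen in a ring. Within the data shown here, the steps that bear on this change are the two that likewise replace cyclohexyl on the same ring nitrogen, namely a 1.1-fold higher number from compound 1 to compound 2 (0.04 log units; within the scatter) and a 1.8-fold lower number from compound 1 to compound 3 (0.27 log units; within the scatter), and both stayed within the scatter. Nothing in these steps gives grounds to expect a move beyond the scatter for compound 4. Compound 4 is therefore expected to show a 1.0-fold lower number from compound 1 to compound 4 (0.02 log units; within the scatter). Compound 4 is estimated at 4500 nM, with a range from 1800 nM to 11000 nM.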

Compound 4, half-maximal inhibitory concentration: 4010 nM
Estimate against measurement, compound 4: 1.1-fold (0.05 log units) above; measured number inside the range.
By their numbers in this assay, from the lowest: compounds 3, 4, 1 and 2 (each within the scatter of the next).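

In this assay, among these compounds, the pyrimidin-2-yl group, the first group on this ring nitrogen with hetero atoms in its ring and with hydrogen-bond acceptors in that ring, gives a 1.2-fold lower number from compound 1 to compound 4 (0.07 log units; within the scatter) against cyclohexyl. Set against the two other aromatic groups, it gives a 1.3-fold lower number from compound 2 to compound 4 (0.11 log units; within the scatter) and a 1.6-fold higher number from compound 3 to compound 4 (0.20 log units; within the scatter), so the position now spans saturated carbon, substituted phenyl and a two-nitrogen aromatic ring, with every step among the four compounds within the scatter. No further measurement on these compounds bears on this result.

The compounds shown leave open whether a group of another kind on this nitrogen, such as a carboxylic acid, an amine-bearing chain or a small methyl group, would give a step beyond the scatter. They also leave open whether the same flat picture would hold with changes elsewhere on the shared core.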